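The source may hold more compounds than are shown below. What is called first, only, known or untested is meant among the compounds shown, and "the series" means these compounds.

Compound 1 `Nc1scc(CN2CCN(c3ccc(Cl)cc3Cl)CC2)c1C(=O)c1ccc(Cl)cc1` carries a 2,4-dichlorophenyl group on an amine nitrogen in a ring of its shared core. In a functional assay on CHO cells with adenosine receptor A1 (Homo sapiens) as the target, read by cAMP accumulation and immunoassay, with a stated time of 6 min, tested at 0.1 uM (on this read-out higher numbers stand for a weaker effect at the one concentration tested and lower numbers for a stronger effect), compound 1 gives -11%. Among the three measured compounds it stands second highest on the numbers: compound 2 `Nc1scc(CN2CCN(c3ccc(Cl)cc3F)CC2)c1C(=O)c1ccc(Cl)cc1` gives -9.4%, and compound 3 `Nc1scc(CN2CCN(c3ccc(F)cc3F)CC2)c1C(=O)c1ccc(Cl)cc1` gives -17%. The gaps between them are all small, with a number 1.6 percentage points higher from compound 1 to compound 2 (within the scatter), a number 6 percentage points lower from compound 1 to compound 3 (within the scatter) and a number 7.6 percentage points lower from compound 2 to compound 3 (within the scatter), each within the scatter. Compound 4 `Nc1scc(CN2CCN(c3cc(F)cc(F)c3)CC2)c1C(=O)c1ccc(Cl)cc1` differs from compound 1 in one place: 3,5-difluorophenyl in place of 2,4-dichlorophenyl on an amine nitrogen in a ring. The measured steps that bear on this change are those that exchange chloro for fluoro on the aromatic ring attached to that nitrogen, namely a number 6 percentage points lower from compound 1 to compound 3 (within the scatter) and a number 7.6 percentage points lower from compound 2 to compound 3 (within the scatter), and neither moved beyond the scatter. For the measured compounds named here, no measured compound carries a 3,5-difluorophenyl group, so that part of the change is untested, which argues for a wider range rather than a shift. The expected step, a number 1 percentage points lower from compound 1 to compound 4 (within the scatter), therefore stays within the scatter in this assay. The estimate for compound 4 is -12%, with a range from -30% to 6%.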

Compound 4, a percentage reported as activity, at one concentration (the size of the read-out at that concentration, not a potency): -5%
Estimate against measurement, compound 4: 7 percentage points below, within the range that was stated.
By their numbers in this assay, from the lowest: compounds 3, 1, 2 and 4 (each within the scatter of the next, the first and the last beyond it).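

In this assay, the 3,5-difluorophenyl group on the ring nitrogen stays within the scatter of both chlorine-bearing groups, with a number 6 percentage points higher from compound 1 to compound 4 (within the scatter) and a number 4.4 percentage points higher from compound 2 to compound 4 (within the scatter), so neither comparison separates it from them. For the compounds shown here, the new information comes from the comparison with the 2,4-difluorophenyl group: a number 12 percentage points higher from compound 3 to compound 4 (beyond the scatter) is the first step at this position to pass beyond the scatter, although only modestly, and it shows that two difluorophenyl groups need not read alike, with the higher number standing for a weaker effect at the one concentration tested. Nothing available explains this difference between the two difluorophenyl groups.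

The compounds shown leave open whether the same difference would appear with a 3,5-dichlorophenyl group, and how an unsubstituted phenyl or a 3,5-dimethoxyphenyl group would read on the same nitrogen. On these data alone, each read-out also comes from a single concentration, so it remains open whether the gap seen here would carry over to a full measure of potency or to a core with a different group in place of the 4-chlorobenzoyl.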